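The source may report more compounds than this note shows. Statements on the series, on what has been measured and on what is new or still open speak of the compounds shown alone.

Compound 1 `Cc1cc(/N=c2\[nH]c(=O)n(C[C@H](C)C(=O)O)c(=O)n2Cc2ccc(Cl)cc2)ccc1OC(C)C` is measured in an ADME assay on the whole organism (plasma, Rattus norvegicus) for protein binding, using cassette dosing, at a dose of 1 mg/kg (a lower number here means a smaller unbound share, a higher number a larger unbound share of the compound), where compound 1 gives 0.02. Two other compounds share its core but carry a different group on oxygen: compound 2 `C[C@@H](Cn1c(=O)[nH]/c(=N\c2ccc(Oc3cncc(F)c3)cc2)n(Cc2ccc(Cl)cc2)c1=O)C(=O)O` gives 0.02, and compound 3 `C[C@@H](Cn1c(=O)[nH]/c(=N\c2ccc(Oc3cnccn3)cc2)n(Cc2ccc(Cl)cc2)c1=O)C(=O)O` gives 0.018. Compound 1 therefore sits level with compound 2 at these digits, and all three values lie within the scatter of one another.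

Compound 4 `CC(C)Oc1ccc(/N=c2\[nH]c(=O)n(C[C@H](C)C(=O)O)c(=O)n2Cc2ccc(Cl)cc2)cc1Cl` differs from compound 1 in one place: chloro in place of methyl on an aromatic carbon. This is chloro in place of methyl on an aromatic carbon, ortho to an isopropoxy group, so 4-isopropoxy-3-methylphenyl becomes 3-chloro-4-isopropoxyphenyl.

Within the data shown here, no measured step tests this exact swap, so the evidence is indirect. Among the measured compounds shown here, the only step available is a 1.1-fold lower number from compound 2 to compound 3 (0.05 log units; within the scatter), which puts pyrazin-2-yl in place of 5-fluoropyridin-3-yl on an oxygen on an aromatic ring. That exchange of one ring group for another stayed within the scatter. For a swap of one heavy atom for one heavy atom, no step beyond the scatter is therefore expected in this assay, and no direction can be favoured. The expected step is no change at the digits printed from compound 1 to compound 4 (within the scatter). The estimated value for compound 4 is 0.02, with an expected range from 0.01 to 0.04.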

Compound 4, unbound fraction: 0.003
Estimate against measurement, compound 4: 6.7-fold (0.82 log units) above; the whole stated range lies above it.
By their numbers in this assay, from the lowest: compound 4; then compounds 3, 1 and 2 (each within the scatter of the next).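

The earlier step, a 1.1-fold lower number from compound 2 to compound 3 (0.05 log units; within the scatter), exchanged one ring group for another on oxygen and stayed within the scatter, so it said nothing about the aromatic carbon ortho to an isopropoxy group. In this assay, this carbon proves sensitive: chloro in place of methyl gives a 6.7-fold lower number from compound 1 to compound 4 (0.82 log units; beyond the scatter), a clearly smaller unbound share, even though the swap exchanges just one heavy atom for another and the counts of rings, hydrogen-bond donors and hydrogen-bond acceptors stay the same. Nothing in the available data accounts for the size or direction of this step.

From the compounds shown here alone, with only methyl and chloro to compare, it remains open whether the step belongs to chloro in particular, and a fluoro, a bromo, a methoxy or a plain hydrogen on this same carbon would help to settle that. Going by these compounds, it is also open whether chloro on this carbon would give a step of similar size with a group other than isopropoxy on the oxygen, such as the 5-fluoropyridin-3-yl of compound 2 or the pyrazin-2-yl of compound 3.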